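The compounds below may be only part of what the source reports. "The series", "measured", "known", "first", "only" and "open" are said of these compounds alone.

Compound 1 `Cc1n[nH]c(C(=O)O)c1Cc1ccc(Oc2ccccc2)cc1`: 43%
Compound 2 `Cc1n[nH]c(C(=O)O)c1Cc1ccc(C(N)=O)cc1`: 8%

In an assay on isolated protein for inhibition of 2-Hydroxyacid oxidase 2 (Homo sapiens), tested at 10 uM (on this read-out higher numbers stand for a stronger effect at the one concentration tested and lower numbers for a weaker effect), compound 2 stands lowest of the two numbers; its nearest neighbour is compound 1, which gives 43%. For the measured compounds named here, the one measured step, a number 35 percentage points lower from compound 1 to compound 2 (beyond the scatter), was beyond the scatter. Compound 3 `Cc1n[nH]c(C(=O)O)c1Cc1ccc(-c2ccc(F)cc2)cc1` differs from compound 2 by 4-fluorophenyl in place of carbamoyl on an aromatic carbon. This change removes the carbamoyl that entered in the measured step and brings back an aryl group, though a 4-fluorophenyl rather than a phenoxy, so the size cannot be read off exactly. A rise beyond the scatter is therefore expected: a number 32 percentage points higher from compound 2 to compound 3 (beyond the scatter). Compound 3 is estimated at 40%, in a range from 20% to 65%.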

Compound 3, a percentage reported as inhibition, at one concentration (the size of the read-out at that concentration, not a potency): 25%
For compound 3 the middle estimate is 15 percentage points above the measured one; the measured number falls inside the stated range.
By their numbers in this assay, from the lowest: compound 2; then compound 3; then compound 1.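

Placing an aryl group on this aromatic carbon recovers part of the effect lost with the carbamoyl, with a number 17 percentage points higher from compound 2 to compound 3 (beyond the scatter). The recovery is incomplete, with a number 18 percentage points lower from compound 1 to compound 3 (beyond the scatter), so the 4-fluorophenyl and the phenoxy are not interchangeable here. No available evidence explains this difference.

The change from phenoxy to 4-fluorophenyl removes the linking oxygen and adds a fluorine in one move, and the compounds shown do not separate the two. On these data alone, it also remains open how an unsubstituted phenyl, a benzyloxy or an amine would behave at this position.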